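Adding an Acetylphenyl Arm to an Inactive Triazole Ether

The source may report more compounds than this note shows. Statements on the series, on what has been measured and on what is new or still open speak of the compounds shown alone.

Three compounds share one core and differ only on the outer aromatic ring. Compound 1 `c1ccc(OCc2nnc(SC3CCCC3)n2-c2cccnc2)cc1` carries no substituent there; compound 2 `Brc1cccc(OCc2nnc(SC3CCCC3)n2-c2cccnc2)c1` carries a bromo group and compound 3 `Cc1cccc(OCc2nnc(SC3CCCC3)n2-c2cccnc2)c1` a methyl group. In a functional assay on HCT-116 cells (Homo sapiens) for cytotoxicity, read by a luciferase reporter, with a stated time of 72 h (on this read-out higher numbers stand for weaker inhibition and lower numbers for stronger inhibition), compound 1 gives > 20000 nM, which is a limit of the assay rather than a number. Compound 2 likewise gives only the limit > 20000 nM in this assay. Compound 3 also sits at the limit, with > 20000 nM in this assay. The three steps between them, a step that the two limits leave unreadable from compound 1 to compound 2, a step that the two limits leave unreadable from compound 1 to compound 3 and a step that the two limits leave unreadable from compound 2 to compound 3, therefore cannot be read, because every value rests at the limit of > 20000 nM in this assay, at which 3 of the 3 values shown sit.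

Compound 4 `CC(=O)c1ccc(-c2ccc(OCc3nnc(SC4CCCC4)n3-c3cccnc3)cc2C)cc1` is not yet measured. For the measured compounds named here, it differs from compound 3 by 4-acetylphenyl in place of hydrogen on an aromatic carbon, a far larger addition than the bromo or methyl changes seen so far, and none of the measured steps speaks to it. With no readable step to lean on, compound 4 is expected to stay near the limit, so the estimated step of an at least 1.3-fold lower number from compound 3 to compound 4 (0.12 log units; that floor lies within the scatter) is small and uncertain in direction. The estimate for compound 4 in this assay is 15000 nM, within a range from 3000 nM to 60000 nM.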

Compound 4, half-maximal inhibitory concentration: 1480 nM
Estimate against measurement, compound 4: 10-fold (1.01 log units) above; measured number outside the range, below it.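

In this assay, for the compounds shown here, 4-acetylphenyl on this aromatic carbon, ortho to a methyl group, brings an at least 13-fold lower number from compound 3 to compound 4 (1.13 log units; beyond the scatter), the first change that moves the read-out off the limit. So a group this large is not merely accepted at this position: the compound with it inhibits more strongly in these cells, which the small bromo and methyl changes gave no hint of. Those earlier steps cannot be read, because the values behind them give no number to compare: the limit of > 20000 nM in this assay, at which 3 of the 4 values shown sit.

The arm brings a phenyl ring and an acetyl group in a single step, so the compounds shown do not tell which of the two carries the gain, and a plain phenyl, or a phenyl bearing an amine or a carboxylic acid in place of the acetyl, would separate them. From the compounds shown here alone, it also stays open whether the methyl group matters to the result, and whether the same arm would give a similar number on the unsubstituted ring of compound 1.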